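The source may hold more compounds than are shown below. What is called first, only, known or untested is meant among the compounds shown, and "the series" means these compounds.

Measured in a functional assay on HCT-116 cells (Homo sapiens) for inhibition, read by MTT assay, with a stated time of 48 h; a higher number here means a weaker inhibitor, a lower number a stronger inhibitor:

compound 1 `C=C(C)C(=O)N(Cc1ccc(OC)c(O)c1)c1cc(OC)c(OC)c(OC)c1` gives 200 nM
compound 2 `COc1ccc(N(Cc2cc(OC)c(OC)c(OC)c2)C(=O)CCl)cc1O` gives 22500 nM
compound 3 `C/C=C/C(=O)N(Cc1ccc(OC)cc1)c1cc(OC)c(OC)c(OC)c1` gives 500 nM

Compound 1 has the lowest number of the three. Compound 3 stands nearest to it, with a higher number that lies beyond the scatter; compound 2 stands furthest, with a far higher number. Compound 4 `CCCCC(=O)N(Cc1ccc(OC)c(O)c1)c1cc(OC)c(OC)c(OC)c1` has not yet been measured in this assay. It differs from compound 1 by butyl in place of 1-methylethenyl on a carbonyl carbon. Among the compounds with values here, no pair of measured compounds shares this change, so nothing measured here tells how large the step should be. A moderate rise in the number, beyond the scatter, is expected as the step of a 5.0-fold higher number from compound 1 to compound 4 (0.70 log units; beyond the scatter). Compound 4 is thus estimated at about 1000 nM, within a range from 250 nM to 5000 nM.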

Compound 4, half-maximal inhibitory concentration: 170 nM
Estimate against measurement, compound 4: 5.9-fold (0.77 log units) above; the measured number lies below the stated range.
By their numbers in this assay, from the lowest: compounds 4 and 1 (each within the scatter of the next); then compound 3; then compound 2.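

In this assay butyl in place of 1-methylethenyl on a carbonyl carbon gives a 1.2-fold lower number from compound 1 to compound 4 (0.07 log units; within the scatter) and so, for this pair, the double bond of the 1-methylethenyl group is not required to keep the number of compound 1. This position therefore accepts a saturated open chain as well as the branched unsaturated group. No available evidence bears on why the two groups read alike. Still open, going by these compounds, is whether a longer chain at this carbonyl carbon would hold the number. An amine or a carboxylic acid on the end of the butyl chain also remains untested in the compounds shown.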